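Chloro added to an amide aryl: expected cell toxicity

The source may report more compounds than this note shows. Statements on the series, on what has been measured and on what is new or still open speak of the compounds shown alone.

Compound 1 `COc1cc(-c2nn(-c3cccc(NC(=O)Nc4cc(C(F)(F)F)cc(C(F)(F)F)c4)c3)cc2-c2ccncc2)ccc1Cl`: 3390 nM
Compound 2 `COc1cc(-c2nn(-c3cccc(NC(=O)c4cccc(C(F)(F)F)c4)c3)cc2-c2ccncc2)ccc1Cl`: > 50000 nM, a limit of the assay
Compound 3 `O=C(Nc1cccc(-n2cc(-c3ccncc3)c(-c3ccc(Cl)c(O)c3)n2)c1)Nc1ccc(Cl)c(Cl)c1`: > 32500 nM, a limit of the assay

In a functional assay on OVCAR-3 cells (Homo sapiens) for inhibition, read by sulforhodamine B assay, with a stated time of 48 h (on this read-out higher numbers stand for lower toxicity in this test and lower numbers for higher toxicity in this test), compound 1 gives 3390 nM, a measured number. Compound 2 reaches only a limit of this assay, > 50000 nM, so no number is known for it. Compound 3 likewise stops at a limit of this assay, > 32500 nM. Compound 2 thus stands at the top of the shown values, at the limit of > 50000 nM in this assay, at which 1 of the 3 values shown sits, and compound 3 sits at the limit of > 32500 nM in this assay, at which 1 of the 3 values shown sits; only compound 1 has a real number, and no single-change step between measured compounds is available.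

Compound 4 `COc1cc(-c2nn(-c3cccc(NC(=O)c4ccc(Cl)c(C(F)(F)F)c4)c3)cc2-c2ccncc2)ccc1Cl` differs from compound 2 in one place: chloro in place of hydrogen on an aromatic carbon. Since compound 2 gives only a limit, the step from it is expected to be small, with no direction claimed beyond the scatter, and the expected step is an at least 1.2-fold lower number from compound 2 to compound 4 (0.09 log units; that floor lies within the scatter). Compound 4 is estimated at 40000 nM, between 10000 nM and 100000 nM, and most likely it too will be reported only as a limit.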

Compound 4, concentration lethal to 50% of the cells: > 32500 nM
Compound 4 ended at the assay's limit (the forecaster's own chance of this, stated with the estimate: 60%); the middle value is on the limit's open side.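

For the compounds shown here, compound 2 and compound 4 both stop at a limit of this assay, not at a real number, and no step from one to the other can be read. The compounds shown leave open whether chloro in place of hydrogen, turning 3-(trifluoromethyl)phenyl into 4-chloro-3-(trifluoromethyl)phenyl, changes toxicity in this test at all.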